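Replacing the 3-chloropropyl group on the shared core

The source may report more compounds than this note shows. Statements on the series, on what has been measured and on what is new or still open speak of the compounds shown alone.

Compound 1 `O=C1O[C@H]([C@@H](O)Cn2cc(-c3cc(F)cc(F)c3)nn2)C(OCc2ccccc2)=C1OCc1ccccc1` sits at a limit in an ADME assay on HFF cells (Homo sapiens) for cytotoxicity, read by MTT assay, with a stated time of 72 h; on this read-out lower numbers stand for stronger inhibition and higher numbers for weaker inhibition: compound 1 gives > 100000 nM.
Compound 2 `O=C1O[C@H]([C@@H](O)Cn2cc(CNS(=O)(=O)c3ccc(F)cc3)nn2)C(OCc2ccccc2)=C1OCc1ccccc1` in this assay gives 30 nM.
Compound 3 `O=C1O[C@H]([C@@H](O)Cn2cc(CCCCl)nn2)C(OCc2ccccc2)=C1OCc1ccccc1` in this assay gives 27100 nM.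

Compound 3 holds the highest of the two actual numbers; its nearest neighbour is compound 2, and the gap is a 900-fold higher number from compound 2 to compound 3 (2.96 log units; beyond the scatter). Compound 1 stands at the limit of > 100000 nM in this assay, at which 1 of the 3 values shown sits.

Compound 4 `O=C1O[C@H]([C@@H](O)Cn2cc(-c3ccc(Br)cc3)nn2)C(OCc2ccccc2)=C1OCc1ccccc1` is not yet measured. It differs from compound 3 by 4-bromophenyl in place of 3-chloropropyl on an aromatic carbon. The measured step that bears on this is an at least 3.6-fold lower number from compound 1 to compound 3 (0.56 log units; beyond the scatter), where an aromatic ring gave way to a chain. The present change puts an aromatic ring back in that position, so the number is expected to move upward again, possibly reaching the limit. Compound 4 is therefore expected near 80000 nM, within 20000 nM to 300000 nM, which means an expected 3.0-fold higher number from compound 3 to compound 4 (0.47 log units; beyond the scatter).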

Compound 4, half-maximal inhibitory concentration: 5100 nM
Beside the measured number, compound 4's estimate is 16-fold (1.20 log units) above it, and the stated range ends above it.
By their numbers in this assay, from the lowest: compound 2; then compound 4; then compound 3. At a limit, above all of these: compound 1.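

On this aromatic carbon, 4-bromophenyl in place of 3-chloropropyl gives a 5.3-fold lower number from compound 3 to compound 4 (0.73 log units; beyond the scatter), so an aromatic ring here does not by itself lead to a higher number. The ring's substitution also counts, with an at least 19-fold lower number from compound 1 to compound 4 (1.29 log units; beyond the scatter), and the first value in that step is a limit: the limit of > 100000 nM in this assay, at which 1 of the 4 values shown sits.
Even so, 4-bromophenyl stays far from (((4-fluorophenyl)sulfonyl)amino)methyl, with a 170-fold higher number from compound 2 to compound 4 (2.23 log units; beyond the scatter).

Still open, as far as these compounds go, is whether the bromine or the ring accounts for the step, which a plain phenyl would test. Also open, from the compounds shown here alone, is how an amine or a carboxylic acid at the end of a chain here would read.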